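This account rests on a few compounds, and the source may have more. Where it says the series, first, only, none or still open, it means among the compounds named here.

Working notes on the series

Compound 1 `CCCn1c(=O)n(CC(=O)O)c(=O)c2[nH]cnc21` carries a carboxy group on the saturated chain carbon bound to an aromatic nitrogen of the shared core. For the measured compounds named here, in a functional assay (trachea) with Cavia porcellus as the target (on this read-out lower numbers stand for an effect already at smaller amounts and higher numbers for an effect only at larger amounts of compound), compound 1 gives 41000 nM, the highest of the three numbers measured so far. Compound 2 `CCCn1c(=O)n(CCCN(C)C)c(=O)c2[nH]cnc21` gives 20500 nM in this assay, and the step of a 2.0-fold lower number from compound 1 to compound 2 (0.30 log units; within the scatter) is within the scatter. Compound 3 `CCCn1c(=O)n(CCO)c(=O)c2[nH]cnc21` gives 510 nM, and the step of an 80-fold lower number from compound 1 to compound 3 (1.91 log units; beyond the scatter) is large; the step of a 40-fold lower number from compound 2 to compound 3 (1.60 log units; beyond the scatter) is large as well.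

Compound 4 `CCCn1c(=O)n(CCCCC(C)=O)c(=O)c2[nH]cnc21` is the next change at the same place: 3-acetylpropyl in place of carboxy on a saturated chain carbon bound to an aromatic nitrogen. Both earlier steps from compound 1 replaced the carboxy group; the step of a 2.0-fold lower number from compound 1 to compound 2 (0.30 log units; within the scatter) stayed within the scatter, whereas the step of an 80-fold lower number from compound 1 to compound 3 (1.91 log units; beyond the scatter) was large. The 3-acetylpropyl group resembles neither the hydroxymethyl group of compound 3 nor the 2-(dimethylamino)ethyl group of compound 2, so the expectation for compound 4 is set between those outcomes. The estimated step is a 5.1-fold lower number from compound 1 to compound 4 (0.71 log units; beyond the scatter), a lower number expected in this assay. For compound 4 the estimate is 8000 nM, with a range from 1500 nM to 40000 nM.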

Compound 4, half-maximal effective concentration: 60 nM
For compound 4 the middle estimate is 130-fold (2.12 log units) above the measured one; measured number outside the range, below it.
By their numbers in this assay, from the lowest: compound 4; then compound 3; then compounds 2 and 1 (each within the scatter of the next).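

At this place, on a saturated chain carbon bound to an aromatic nitrogen, the 3-acetylpropyl group gives the lowest number of the four in this assay, with a 680-fold lower number from compound 1 to compound 4 (2.83 log units; beyond the scatter) and a 340-fold lower number from compound 2 to compound 4 (2.53 log units; beyond the scatter), and it also goes past the hydroxy-ended chain, with an 8.5-fold lower number from compound 3 to compound 4 (0.93 log units; beyond the scatter). So the hydroxy-ended chain of compound 3 is not the only replacement of carboxy that lowers the number, and since carboxy and 3-acetylpropyl match in hydrogen-bond acceptors and in double bonds outside aromatic rings, neither count alone follows the step. No measured evidence bears on why this change has so large a step.

As far as these compounds go, compound 4 differs from the others in both chain length and end group, so their shares in the step remain open. A plain pentyl chain, without the carbonyl, or a hydroxy group at the end of a longer chain would separate the two.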